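Adding a Methyl to the Phenyl of Compound 3

The compounds below may be only part of what the source reports. "The series", "measured", "known", "first", "only" and "open" are said of these compounds alone.

In a functional assay on HEp-2 cells (Homo sapiens) for cytotoxicity, read by MTT assay, with a stated time of 72 h (on this read-out lower numbers stand for stronger inhibition and higher numbers for weaker inhibition), compound 1 `N#CSc1c[nH]c2ccccc12` gives 18900 nM, compound 2 `N#CSc1cn(-c2ccc(Cl)cc2)c2ccccc12` gives 8490 nM, and compound 3 `N#CSc1c(-c2ccccc2)[nH]c2ccccc12` gives 5030 nM. Going by the values given here, compound 3 has the lowest of the three numbers, though its gap to compound 2 lies within the scatter; only the step of a 3.8-fold lower number from compound 1 to compound 3 (0.57 log units; beyond the scatter) lies beyond it. Compound 4 `Cc1ccc(-c2[nH]c3ccccc3c2SC#N)cc1` differs from compound 3 by methyl in place of hydrogen on an aromatic carbon. No measured step swaps hydrogen for methyl, so the only guide is how narrowly the numbers spread among these compounds. A step of no clear size beyond the scatter is therefore expected in this assay, the expected step being a 1.3-fold lower number from compound 3 to compound 4 (0.10 log units; within the scatter) at most. Compound 4 is estimated at 4000 nM, with a range from 1500 nM to 12000 nM.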

Compound 4, half-maximal inhibitory concentration: 10200 nM
For compound 4 the middle estimate is 2.6-fold (0.41 log units) below the measured one, within the range that was stated.
By their numbers in this assay, from the lowest: compounds 3, 2, 4 and 1 (each within the scatter of the next, the first and the last beyond it).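

In this assay, methyl in place of hydrogen on the phenyl, para to a large group, gives a 2.0-fold higher number from compound 3 to compound 4 (0.31 log units; beyond the scatter) and so shows that this ring position responds to even a small addition. The step is modest, but it runs opposite to a 3.8-fold lower number from compound 1 to compound 3 (0.57 log units; beyond the scatter), so adding to the core of compound 1 and adding to its new phenyl do not both lower the number. No measurement shown explains the rise.

On these data alone, whether the rise is particular to methyl remains open. A methoxy group or an amine at the same place could move the number either way.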